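Swapping the Aryl Substituent on the Amide of Compound 2

This account rests on a few compounds, and the source may have more. Where it says the series, first, only, none or still open, it means among the compounds named here.

Going by the values given here, in an assay on CHO cells for displacement of a labelled ligand from prostaglandin D2 receptor (Mus musculus), read by scintillation counting, with a stated time of 60 min (on this read-out higher numbers stand for weaker inhibition and lower numbers for stronger inhibition), compound 2 `Cc1ccc(CC(=O)O)cc1NC(=O)c1ccc(OC[C@@H]2CN(C)c3ccccc3O2)cc1Cl` gives 26 nM, the lowest of the two numbers known so far. Compound 1 `CN1C[C@@H](COc2ccc(C(=O)N(C)c3cccc(CC(=O)O)c3)cc2)Oc2ccccc21` gives 760 nM, a higher number that lies beyond the usual scatter. Compound 3 `CN1C[C@@H](COc2ccc(C(=O)Nc3ccc(F)c(CC(=O)O)c3)c(Cl)c2)Oc2ccccc21` has not been measured. It differs from compound 2 by 3-(carboxymethyl)-4-fluorophenyl in place of 5-(carboxymethyl)-2-methylphenyl on an amide-type nitrogen. Among the compounds with values here, no measured pair shows this exact change, so compound 3 is expected to shift by a 2.3-fold higher number from compound 2 to compound 3 (0.36 log units; beyond the scatter) in this assay, a modest move toward a higher number. Compound 3 is estimated at 60 nM, within a range from 15 nM to 250 nM.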

Compound 3, inhibition constant: 25 nM
Compound 3: the middle estimate sits 2.4-fold (0.38 log units) above what was measured, within the range that was stated.
By their numbers in this assay, from the lowest: compounds 3 and 2 (each within the scatter of the next); then compound 1.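

In this assay, 3-(carboxymethyl)-4-fluorophenyl in place of 5-(carboxymethyl)-2-methylphenyl on an amide-type nitrogen gives a 1.0-fold lower number from compound 2 to compound 3 (0.02 log units; within the scatter), so at this position the two aryl groups read alike. Going by these compounds alone, compound 1 differs from compound 2 in more than one place, so the earlier compounds could not show this. Nothing available accounts for this result.

Still open, on these data alone, is how a trifluoromethyl group in place of the fluorine of compound 3 would read. Also open, as far as these compounds go, is whether a propanoic acid chain could replace the carboxymethyl group at this position.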